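The source may hold more compounds than are shown below. What is called first, only, known or untested is meant among the compounds shown, and "the series" means these compounds.

Compound 1 `C[C@@H](O)[C@H]1C(=O)N2C(C(=O)OCOC(=O)OC3Cc4ccccc4C3)=C(S[C@@H]3CN[C@H](C(=O)N(C)C)C3)[C@H](C)[C@H]12` gives 0.015 h in an ADME assay on a cell-free system (plasma, Cavia porcellus, strain Dunkin-Hartley) for metabolic stability, read by HPLC, tested at 5 mM; on this read-out higher numbers stand for a longer-lived compound and lower numbers for a shorter-lived compound.
Compound 2 `CC(C)OC(=O)OC(C)OC(=O)C1=C(S[C@@H]2CN[C@H](C(=O)N(C)C)C2)[C@H](C)[C@@H]2[C@@H]([C@@H](C)O)C(=O)N12` gives 0.0233 h; 0.108 h (2 entries) in this assay.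
Compound 3 `C[C@@H](O)[C@H]1C(=O)N2C(C(=O)OCOC(=O)O[C@H]3CCCCc4ccccc43)=C(S[C@@H]3CN[C@H](C(=O)N(C)C)C3)[C@H](C)[C@H]12` gives 0.0217 h in this assay.

Compound 3 is one of two compounds with a single number in this assay; its nearest neighbour is compound 1, and the two lie within the scatter of each other. The two entries of compound 2 the several entries of compound 2 in this assay, 0.0233 h; 0.108 h (2 entries) show how far repeat measurements of this kind can spread. Compound 4 `C[C@@H](O)[C@H]1C(=O)N2C(C(=O)OCOC(=O)OC3CCc4ccccc4C3)=C(S[C@@H]3CN[C@H](C(=O)N(C)C)C3)[C@H](C)[C@H]12` differs from compound 3 by a group of 10 heavy atoms (10 carbon; one six-membered non-aromatic ring of carbon only, one six-membered aromatic ring of carbon only) in place of a group of 11 heavy atoms (11 carbon; one six-membered aromatic ring of carbon only, one seven-membered non-aromatic ring of carbon only), on an oxygen next to a carbonyl group. Among the compounds with values here, the only comparable step, a 1.4-fold higher number from compound 1 to compound 3 (0.16 log units; within the scatter), also exchanged this group and stayed within the scatter, so no step beyond the scatter is expected in this assay. Compound 4 is therefore expected to give about 0.02 h, between 0.008 h and 0.06 h, which means a 1.1-fold lower number from compound 3 to compound 4 (0.04 log units; within the scatter).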

Compound 4, half-life: 0.0283 h
Compound 4: the middle estimate sits 1.4-fold (0.15 log units) below what was measured; measured number inside the range.
By their numbers in this assay, from the lowest: compounds 1, 3 and 4 (each within the scatter of the next).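

With 1,2,3,4-tetrahydronaphthalen-2-yl on the oxygen next to a carbonyl group, the result gives a 1.3-fold higher number from compound 3 to compound 4 (0.12 log units; within the scatter) and a 1.9-fold higher number from compound 1 to compound 4 (0.28 log units; within the scatter) in this assay. Five-, six- and seven-membered non-aromatic rings in this group have now all been read, and no two of them separate beyond the scatter, with the widest step smaller than the spread between repeat readings: the several entries of compound 2 in this assay, 0.0233 h; 0.108 h (2 entries). The compounds shown leave open whether a cyclohexyl group without the aromatic ring, or a ring carrying an amine or a carboxylic acid, would move the half-life beyond the scatter.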